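Replacing benzyloxy on the shared core

The source may report more compounds than this note shows. Statements on the series, on what has been measured and on what is new or still open speak of the compounds shown alone.

- compound 1 (`COC1=CC(=O)c2c(c(CO)cn2C)C1=O`) gives 220000 nM
- compound 2 (`COC1=CC(=O)c2c(c(COCc3ccccc3)c(C)n2C)C1=O`) gives 225000 nM

For the measured compounds named here, in a functional assay on V79-379A cells (Cricetulus griseus) for cytotoxicity, read by MTT assay, in the presence of a further agent that is not named here (on this read-out higher numbers stand for weaker inhibition and lower numbers for stronger inhibition), only these two compounds have numbers so far, and compound 2 (225000 nM) stands within the usual scatter of compound 1 (220000 nM). Compound 3 (`COC1=CC(=O)c2c(c(Cc3ccc(O)c(F)c3)c(C)n2C)C1=O`) has not yet been measured. It carries 3-fluoro-4-hydroxyphenyl in place of benzyloxy on a saturated chain carbon bound to an aromatic carbon. Going by the values given here, no measured pair differs in one place only, so the data offer no single step as a guide, only the close agreement of the two values. The expected step of a 1.3-fold lower number from compound 2 to compound 3 (0.10 log units; within the scatter) in this assay is therefore none beyond the scatter, in no firm direction. For compound 3 the estimated value is 180000 nM (expected range 50000 nM to 450000 nM).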

Compound 3, half-maximal inhibitory concentration: 470000 nM
Compound 3: the middle estimate sits 2.6-fold (0.42 log units) below what was measured, and the stated range ends below it.
By their numbers in this assay, from the lowest: compounds 1 and 2 (each within the scatter of the next); then compound 3.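

In this assay the exchange of benzyloxy for 3-fluoro-4-hydroxyphenyl on a saturated chain carbon bound to an aromatic carbon gives a 2.1-fold higher number from compound 2 to compound 3 (0.32 log units; beyond the scatter) and so points towards weaker inhibition. For the compounds shown here, this is the first single change that can be read here, and it shows that the number responds to the group at this place even though both groups have the same count of heavy atoms and one six-membered aromatic ring each. Nothing measured here accounts for the step.

Which part of the change carries the step stays open: the hydroxy group, the fluorine or the loss of the benzyloxy oxygen. The compounds shown also do not tell how an unsubstituted phenyl, an amine or a carboxylic acid on the same chain carbon would read.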